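A few compounds are considered here, and "the series" means these few. Any claim that something is new, unique, unknown or untested is made for them only; others in the source may bear on it.

Measured in an ADME assay on MDBK cells (Bos taurus) for cytotoxicity; a lower number here means that less compound is tolerated, a higher number that more compound is tolerated:
compound 1 `Fc1cccc(Cn2ccc3nc(-c4ccccc4)nc-3c2)c1`: > 100000 nM (a limit of the assay)
compound 2 `Ic1ccc(Cn2ccc3nc(-c4ccccc4)nc-3c2)cc1`: 22000 nM

Going by the values given here, compound 2 holds the only true number so far, and it can be read only against the limit of compound 1. Compound 3 `CCC(CC)Cn1ccc2nc(-c3ccccc3)nc-2c1` differs from it by pentan-3-yl in place of 4-iodophenyl on a saturated chain carbon bound to an aromatic nitrogen. Going by these compounds, one measured step changes the same place, an at least 4.5-fold lower number from compound 1 to compound 2 (0.65 log units; beyond the scatter), and its full size stays open given (the limit of > 100000 nM in this assay, at which 1 of the 2 values shown sits). On that step, a modest move to a higher number in this assay is expected. The expected step is a 2.3-fold higher number from compound 2 to compound 3 (0.36 log units; beyond the scatter). For compound 3 the estimate is 50000 nM, with an expected range of 18000 nM to 130000 nM.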

Compound 3, half-maximal cytotoxic concentration: > 100000 nM
Compound 3: no number, only a limit (the forecaster's own chance of this, stated with the estimate: 35%); middle value at least 2.0-fold (0.30 log units) from the limit.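

In this assay, pentan-3-yl in place of 4-iodophenyl on a saturated chain carbon bound to an aromatic nitrogen gives an at least 4.5-fold higher number from compound 2 to compound 3 (0.65 log units; beyond the scatter), so a group with no ring also reaches the top of the readable range. Compound 3 gives > 100000 nM, which is a limit of the assay. Compound 1 and compound 3 cannot be ordered, and the step between them cannot be read: the limit of > 100000 nM in this assay, at which 2 of the 3 values shown sit.

Still open, going by these compounds, is whether the lower number of compound 2 comes from the iodine or from its placing on the phenyl ring. On these data alone, how an amine or a carboxylic acid at this place would read is also open.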